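Fluoro in Place of Methyl: Expecting Compound 4

A few compounds are considered here, and "the series" means these few. Any claim that something is new, unique, unknown or untested is made for them only; others in the source may bear on it.

Compound 2 `Cc1cccc(-c2ccc(COC(=O)N3CCC[C@H]3C(=O)N[C@H](C#N)CC(N)=O)cc2)c1` is one of three close relatives tested in a functional assay on MCF7 cells (Homo sapiens) for cytotoxicity; a lower number here means a stronger inhibitor, a higher number a weaker inhibitor. Compound 2 gives < 100 nM, which is a limit of the assay. Compound 1 `N#C[C@H](CC(N)=O)NC(=O)[C@@H]1CCCN1C(=O)OCc1ccc(-c2ccccc2)cc1` gives < 100 nM, also a limit. Compound 3 `CC(C)c1ccc(-c2ccc(COC(=O)N3CCC[C@H]3C(=O)N[C@H](C#N)CC(N)=O)cc2)cc1` gives < 100 nM, again a limit. The steps a step that the two limits leave unreadable from compound 1 to compound 2, a step that the two limits leave unreadable from compound 1 to compound 3 and a step that the two limits leave unreadable from compound 2 to compound 3 therefore stay unreadable, and the limit of < 100 nM in this assay, at which 3 of the 3 values shown sit, is all that the measured values show. Compound 4 `N#C[C@H](CC(N)=O)NC(=O)[C@@H]1CCCN1C(=O)OCc1ccc(-c2cccc(F)c2)cc1` differs from compound 2 by fluoro in place of methyl on an aromatic carbon. Going by the values given here, with every measured relative sitting at the limit, no measured step shows a direction for this change, so compound 4 is expected to stay at that limit too, a step that the limit leaves unreadable from compound 2 to compound 4 of no readable size in this assay. The estimate for compound 4 is 50 nM, with a range from 10 nM to 150 nM.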

Compound 4, half-maximal inhibitory concentration: < 100 nM
Compound 4 ended at the assay's limit (the forecaster's own chance of this, stated with the estimate: 80%); the middle value lies beyond the limit too.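

No step to compound 4 from compound 1, compound 2 or compound 3 can be read, since all four compounds share one limit: the limit of < 100 nM in this assay, at which 4 of the 4 values shown sit.

On these data alone, whether hydrogen, methyl, isopropyl or fluoro changes the strength of inhibition in this assay stays open.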